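Metabolic stability after replacing a large nitrogen substituent

The source may hold more compounds than are shown below. What is called first, only, known or untested is meant among the compounds shown, and "the series" means these compounds.

Measured so far in an ADME assay on microsomes from liver (Rattus norvegicus) for metabolic stability, with a stated time of 60 min; on this read-out higher numbers stand for a more stable compound and lower numbers for a less stable compound
- Compound 1 `O=C(O)c1cc(-c2cccc(COc3ccc4c(=O)n(C5CCCC5)oc4c3)c2)ccc1Cl` gives 35%
- Compound 2 `O=C(O)c1cc(-c2cccc(COc3ccc4c(c3)CN(Cc3ccc(C(F)(F)F)cc3)C4=O)c2)ccc1Cl` gives 100%
- Compound 3 `CC(C)CN1Cc2cc(OCc3cccc(-c4ccc(Cl)c(C(=O)O)c4)c3)ccc2C1=O` gives 43%

Compound 2 stands highest of the three in this assay, and both other compounds lie beyond the scatter from it. Compound 4 `O=C(O)c1cc(-c2cccc(COc3ccc4c(c3)CN(C3CC3)C4=O)c2)ccc1Cl` has cyclopropyl in place of 4-(trifluoromethyl)benzyl on an amide-type nitrogen in a ring. Going by the values given here, the one measured step that bears on this is large: a number 57 percentage points lower from compound 2 to compound 3 (beyond the scatter), with isopropyl in place of 4-(trifluoromethyl)phenyl on a saturated chain carbon bound to an amide-type nitrogen in a ring. Among the compounds with values here, no measured compound carries cyclopropyl, so a similar large fall is only an expectation. The expected step is a number 50 percentage points lower from compound 2 to compound 4 (beyond the scatter). The estimated value for compound 4 is 50%, with an expected range from 28% to 75%.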

Compound 4, percent of the compound remaining: 9%
Estimate against measurement, compound 4: 41 percentage points above; measured number outside the range, below it.
By their numbers in this assay, from the lowest: compound 4; then compounds 1 and 3 (each within the scatter of the next); then compound 2.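

In this assay, cyclopropyl in place of 4-(trifluoromethyl)benzyl on the amide-type nitrogen in a ring brings a very large fall (a number 91 percentage points lower from compound 2 to compound 4 (beyond the scatter)). Losing the aromatic ring is not the whole story, since cyclopropyl in place of isobutyl also brings a large fall (a number 34 percentage points lower from compound 3 to compound 4 (beyond the scatter)), and neither compound 3 nor compound 4 has that ring. Nothing available explains why these groups differ. Plain benzyl at this nitrogen would show whether the trifluoromethyl is needed for the high value of compound 2. As far as these compounds go, how a longer chain such as hexyl would fare also remains open.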